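This account rests on a few compounds, and the source may have more. Where it says the series, first, only, none or still open, it means among the compounds named here.

Measured so far in a functional assay on HL-60 cells (Homo sapiens) for inhibition; a lower number here means a stronger inhibitor, a higher number a weaker inhibitor:
Compound 1 `OC[C@H]1OC(n2cnc3c(-c4ccccn4)ncnc32)[C@H](O)[C@@H]1O` gives 5600 nM
Compound 2 `Cc1ccsc1-c1ncnc2c1ncn2C1O[C@H](CO)[C@@H](O)[C@H]1O` gives 4500 nM
Compound 3 `OC[C@H]1OC(n2cnc3c(-c4ccc(F)cc4)ncnc32)[C@H](O)[C@@H]1O` gives 6300 nM

Compound 3 at 6300 nM lies within the scatter of both other compounds. Compound 4 `OC[C@H]1OC(n2cnc3c(-c4cc[nH]n4)ncnc32)[C@H](O)[C@@H]1O` carries 1H-pyrazol-3-yl in place of 4-fluorophenyl on an aromatic carbon and differs thus: 1H-pyrazol-3-yl in place of 4-fluorophenyl on an aromatic carbon. Three measured exchanges at that carbon bear on this change. The steps of a 1.1-fold higher number from compound 1 to compound 3 (0.05 log units; within the scatter) and a 1.4-fold higher number from compound 2 to compound 3 (0.15 log units; within the scatter) and a 1.2-fold lower number from compound 1 to compound 2 (0.09 log units; within the scatter) are all within the scatter. Among the measured compounds shown here, no measured compound carries 1H-pyrazol-3-yl, so the range stays wide. The expected step is therefore none beyond the scatter, estimated as a 1.1-fold lower number from compound 3 to compound 4 (0.02 log units; within the scatter) in this assay. For compound 4 the estimate is 6000 nM with an expected range from 2000 nM to 18000 nM around it.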

Compound 4, half-maximal inhibitory concentration: 1170 nM
Beside the measured number, compound 4's estimate is 5.1-fold (0.71 log units) above it; measured number outside the range, below it.
By their numbers in this assay, from the lowest: compound 4; then compounds 2, 1 and 3 (each within the scatter of the next).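

In this assay the earlier exchanges at this aromatic carbon had all stayed within the scatter, but 1H-pyrazol-3-yl gives a 5.4-fold lower number from compound 3 to compound 4 (0.73 log units; beyond the scatter) and a 3.8-fold lower number from compound 2 to compound 4 (0.59 log units; beyond the scatter) and a 4.8-fold lower number from compound 1 to compound 4 (0.68 log units; beyond the scatter) against the three earlier groups. The position therefore does respond to its substituent, and compound 4 is the strongest inhibitor of the four. Against 4-fluorophenyl, the change brings in a five-membered ring with two nitrogens and a hydrogen-bond donor, and the single exchange cannot separate these features.

On these data alone, whether an amine or 1H-imidazol-2-yl at this carbon would behave like 1H-pyrazol-3-yl remains open. Nothing measured here explains the step.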